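A few compounds are considered here, and "the series" means these few. Any claim that something is new, unique, unknown or untested is made for them only; others in the source may bear on it.

Measured so far in a functional assay on HepG2 cells (Homo sapiens) for antiproliferative activity, read by sulforhodamine B assay, with a stated time of 48 h; on this read-out lower numbers stand for stronger inhibition and higher numbers for weaker inhibition:
- compound 1 `COc1ccc(OC)c(/C=C/C(=O)/C=C(O)/C=C/c2cc(OC)ccc2OC)c1` gives 5560 nM
- compound 2 `COc1ccc(OC)c(/C=C/C(=O)C(=Cc2ccc(OC)c(OC)c2)C(=O)/C=C/c2cc(OC)ccc2OC)c1` gives 260 nM

Of these two numbers, compound 2 holds the lower, which makes it the stronger inhibitor of the pair, and the gap to compound 1 lies beyond the usual scatter of repeated measurements.

The next molecule, compound 3 `COc1ccc(OC)c(/C=C/C(=O)C(=Cc2ccc(OC)c(O)c2)C(=O)/C=C/c2cc(OC)ccc2OC)c1` differs from compound 2 in one place. The change is hydrogen in place of methyl on an oxygen on an aromatic ring and in plain terms it puts hydrogen in place of methyl on an oxygen on an aromatic ring, so that a 3,4-dimethoxyphenyl becomes a 3-hydroxy-4-methoxyphenyl. Within the data shown here, no measured pair here shows this kind of change, so the data do not fix its size or direction. Among the measured compounds shown here, the only close guide is compound 2 at 260 nM and the rest of that molecule stays untouched. On that basis, an estimated 1.2-fold higher number from compound 2 to compound 3 (0.06 log units; within the scatter) is expected to stay within the scatter in this assay with no clear direction. For compound 3 the expected value is 300 nM with an estimated range from 100 nM to 900 nM as the likely span.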

Compound 3, half-maximal inhibitory concentration: 470 nM
The estimate for compound 3 lay 1.6-fold (0.19 log units) below the measured number; low and high end bracket the measured number.
By their numbers in this assay, from the lowest: compounds 2 and 3 (each within the scatter of the next); then compound 1.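

In this assay, among these compounds, the one step on this oxygen reads a 1.8-fold higher number from compound 2 to compound 3 (0.26 log units; within the scatter), so replacing methoxy with hydroxy on the 3,4-dimethoxyphenyl group gives two values that cannot be told apart from ordinary repeat-to-repeat variation. Among the compounds shown here, this is the first direct look at this position, and it shows that, in this molecule and for this single replacement, the methyl can give way to hydrogen without a measurable loss of antiproliferative activity, so the methyl on this oxygen is not required for the activity of compound 2 in this test. Nothing available explains why the two compounds read alike, and with a single pair no general rule for this position can be drawn.

The compounds shown leave open how a larger group on the same oxygen, such as an ethyl or a longer chain, would read, and what an amine or a fluorine would do in place of the hydroxy of compound 3. They also leave open whether the other methoxy groups of the molecule would accept the same swap.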